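This account rests on a few compounds, and the source may have more. Where it says the series, first, only, none or still open, it means among the compounds named here.

Three glucose-derived compounds have been tested in an assay on isolated protein (Oryctolagus cuniculus) for inhibition of glycogen phosphorylase, brain form (Homo sapiens); on this read-out lower numbers stand for stronger inhibition and higher numbers for weaker inhibition. Compound 1 `[N-]=[N+]=NC[C@H]1O[C@H](CO)[C@@H](O)[C@H](O)[C@H]1O` gives 22400000 nM, compound 2 `CNNC(=O)[C@H]1O[C@H](CO)[C@@H](O)[C@H](O)[C@H]1O` gives 1800000 nM, and compound 3 `NC(=O)N[C@H]1O[C@H](CO)[C@@H](O)[C@H](O)[C@H]1O` gives 140000 nM, the lowest of the three numbers, reached through the steps of a 13-fold lower number from compound 2 to compound 3 (1.11 log units; beyond the scatter) and a 160-fold lower number from compound 1 to compound 3 (2.20 log units; beyond the scatter). Compound 4 `NC(=O)CS[C@H]1O[C@H](CO)[C@@H](O)[C@H](O)[C@H]1O` differs from compound 3 in one place: (carbamoylmethyl)sulfanyl in place of ureido on a saturated ring carbon. For the measured compounds named here, no measured pair swaps exactly these two groups, but both earlier steps show that exchanging the group on this ring carbon shifts the numbers strongly, and here the group that gave the lowest number is lost. Weaker inhibition is therefore expected for compound 4, with a step of a 7.1-fold higher number from compound 3 to compound 4 (0.85 log units; beyond the scatter). The estimate for compound 4 is 1000000 nM, ranging from 200000 nM to 5000000 nM.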

Compound 4, inhibition constant: 21100000 nM
Estimate against measurement, compound 4: 21-fold (1.32 log units) below; the whole stated range lies below it.
By their numbers in this assay, from the lowest: compound 3; then compound 2; then compounds 4 and 1 (each within the scatter of the next).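

In this assay, replacing ureido with (carbamoylmethyl)sulfanyl on this ring carbon gives a 150-fold higher number from compound 3 to compound 4 (2.18 log units; beyond the scatter), although both groups hold a carbonyl carrying a terminal nitrogen, so that shared feature alone does not keep the lower number. The new group also falls behind (methylamino)carbamoyl, with a 12-fold higher number from compound 2 to compound 4 (1.07 log units; beyond the scatter), and stands within the scatter of azidomethyl, with a 1.1-fold lower number from compound 1 to compound 4 (0.03 log units; within the scatter). No supporting measurement explains these differences. Still open, on these data alone, is whether the sulfur or the chain carbon matters more, and how an acetamido group or a carboxylic acid would compare on this ring carbon.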